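Sulfonyl aryl halogen swap on the oxadiazole sulfonamide series

The compounds below may be only part of what the source reports. "The series", "measured", "known", "first", "only" and "open" are said of these compounds alone.

Compound 2 `Cc1cn(Cc2ccc(Cl)cc2Cl)c2c(-c3nnc(NS(=O)(=O)c4ccc(Cl)c(Cl)c4)o3)cc(F)cc12` gives 56% in an assay on isolated protein with thromboxane A2 receptor (Homo sapiens) as the target, read by FLIPR, tested at 10 uM (a lower number here means a weaker effect, a higher number a stronger effect of the compound at the concentration tested), the second highest of the three numbers. Compound 1 `Cc1cn(Cc2ccc(Cl)cc2Cl)c2c(-c3nnc(NS(=O)(=O)c4cc(F)c(F)cc4F)o3)cc(F)cc12` gives 99% in this assay, and compound 3 `Cc1cn(Cc2ccc3ccccc3c2)c2c(-c3cc(NS(=O)(=O)c4ccc(F)c(F)c4)no3)cc(F)cc12`, which carries a different core, gives 12%. Among the compounds with values here, the one measured step that touches the aryl group on the sulfonyl sulfur is a number 43 percentage points lower from compound 1 to compound 2 (beyond the scatter), 3,4-dichlorophenyl in place of 2,4,5-trifluorophenyl, a loss beyond the scatter. Compound 4 `Cc1cn(Cc2ccc(Cl)cc2Cl)c2c(-c3nnc(NS(=O)(=O)c4ccc(F)c(F)c4)o3)cc(F)cc12` is not yet measured; it differs from compound 2 by 3,4-difluorophenyl in place of 3,4-dichlorophenyl on a sulfonyl sulfur. Within the data shown here, that is the reverse direction of the only relevant step, chlorines giving way to fluorines on the same sulfonyl aryl group, so a rise in this assay is expected, of a size comparable to the loss seen from compound 1 to compound 2, though the fluorine pattern is not the same and compound 3, with 3,4-difluorophenyl on another core, shows no such strength. For compound 4 the expected value in this assay is 82%, with a range from 50% to 100%, meaning an expected step of a number 26 percentage points higher from compound 2 to compound 4 (beyond the scatter).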

Compound 4, a percentage reported as activity, at one concentration (the size of the read-out at that concentration, not a potency): 89%
Estimate against measurement, compound 4: 7 percentage points below, within the range that was stated.
By their numbers in this assay, from the lowest: compound 3; then compound 2; then compounds 4 and 1 (each within the scatter of the next).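

In this assay, the change on the sulfonyl sulfur from 3,4-dichlorophenyl to 3,4-difluorophenyl is a number 33 percentage points higher from compound 2 to compound 4 (beyond the scatter); unlike the earlier step, it keeps the substitution places and changes only the halogen, so the identity of the halogen alone moves the read-out here. Hydrogen in place of fluoro on an aromatic carbon is a number 10 percentage points lower from compound 1 to compound 4 (within the scatter), so among these compounds on the shared core the two fluorinated aryl groups cannot be told apart, and only the 3,4-dichlorophenyl group of compound 2 stands apart. No measurement at hand explains the difference between the halogens.

On these data alone, compound 3 differs from compound 4 in more than one place, so what the core and the group on its ring nitrogen contribute stays open. Also open, as far as these compounds go, is how an unsubstituted phenyl, a methoxy group or a nitrile on the sulfonyl aryl group would read.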